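Swapping Chloro for Methyl on a Shared Core

The source may hold more compounds than are shown below. What is called first, only, known or untested is meant among the compounds shown, and "the series" means these compounds.

Of the compounds shown here, three have been measured in a physicochemical assay for permeability, using PAMPA, at pH 4; on this read-out lower numbers stand for lower permeability and higher numbers for higher permeability. Compound 1 `CC(C)Nc1nc(NCc2ccco2)c2ccc(Cl)cc2n1` gives 103 10^-6 cm/s. Compound 2 `CC(C)Nc1nc(NCc2ccco2)c2cc(Cl)ccc2n1` gives 170 10^-6 cm/s; compound 1 and compound 2 are built from the same atoms joined differently, and the difference between the two cores is not broken down here. Compound 3 `Cc1ccc2c(NCc3ccco3)nc(NC(C)C)nc2c1` gives 67.2 10^-6 cm/s.

Compound 3 differs from compound 1 by methyl in place of chloro on an aromatic carbon, and that change made a 1.5-fold lower number from compound 1 to compound 3 (0.19 log units; within the scatter).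

Compound 4 `Cc1ccc2nc(NC(C)C)nc(NCc3ccco3)c2c1` is not yet measured. It differs from compound 2 by methyl in place of chloro on an aromatic carbon, the same change as from compound 1 to compound 3, at the same kind of place in the shared core. Among the measured compounds shown here, for this reason the expected step in this assay is a 1.5-fold lower number from compound 2 to compound 4 (0.17 log units; within the scatter), because the one example of this change gave a 1.5-fold lower number from compound 1 to compound 3 (0.19 log units; within the scatter), and the new step is expected to be of about that size, resting on a single precedent and so carrying a broad range. Compound 4 is therefore estimated at 115 10^-6 cm/s, with a likely range from 65 10^-6 cm/s to 200 10^-6 cm/s.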

Compound 4, apparent permeability: 67.2 10^-6 cm/s
Estimate against measurement, compound 4: 1.7-fold (0.23 log units) above; low and high end bracket the measured number.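

In this assay, methyl in place of chloro gave a 2.5-fold lower number from compound 2 to compound 4 (0.40 log units; beyond the scatter), a modest step, and it points the same way as a 1.5-fold lower number from compound 1 to compound 3 (0.19 log units; within the scatter). The direction of the change therefore held on both cores, but only the new step lies beyond the scatter, and two examples can neither fix a reliable size for this change nor show that it would behave alike on any other core. Nothing measured here explains the direction or the size of either step.

The compounds shown carry only chloro and methyl at this place on the aromatic ring, so it remains open how a fluoro, a methoxy or a nitrile group there would move the number. Also open, on these data alone, is whether the change from chloro to methyl would keep its direction in a compound that also carries a carboxylic acid or a longer chain elsewhere on the shared core.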